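The compounds below may be only part of what the source reports. "The series", "measured", "known", "first", "only" and "open" are said of these compounds alone.

Compound 1 `CCCNc1ncnc2c1cnn2-c1ccccc1` in a functional assay on G-361 cells (Homo sapiens) for cytotoxicity, read by sulforhodamine B assay (a lower number here means that less compound is tolerated, a higher number that more compound is tolerated), reaches only the limit of the assay, > 100000 nM. Compound 2 `CCCNc1nc(CC)nc2c1cnn2-c1ccccc1` likewise gives only a limit, > 100000 nM. For the measured compounds named here, the single measured step, a step that the two limits leave unreadable from compound 1 to compound 2, is therefore unreadable. Compound 3 `CCCNc1nc(NCCC)c2cnn(-c3ccccc3)c2n1` differs from compound 2 by propylamino in place of ethyl on an aromatic carbon. Going by the values given here, no measured step bears directly on this change, and both values so far sit at the limit of > 100000 nM in this assay, at which 2 of the 2 values shown sit, so nothing beyond the scatter can be inferred. Compound 3 is expected to remain near the limit, the expected step being a step that the limit leaves unreadable from compound 2 to compound 3. The estimate for compound 3 is 150000 nM, ranging from 30000 nM to 1000000 nM.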

Compound 3, concentration lethal to 50% of the cells: > 100000 nM
Compound 3: no number, only a limit (the forecaster's own chance of this, stated with the estimate: 80%); the middle value does not contradict the limit.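

In this assay compound 3 gives > 100000 nM, which is a limit. No step among compound 1, compound 2 and compound 3 can be read: the limit of > 100000 nM in this assay, at which 3 of the 3 values shown sit.

Left open is whether any change on the shared core gives a numerical value in this assay.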